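Swapping the aryl group on the ring nitrogen

The source may hold more compounds than are shown below. What is called first, only, known or untested is meant among the compounds shown, and "the series" means these compounds.

Measured compounds:
Compound 1 `CCCCNc1nc(C(F)(F)F)ccc1CNC(=O)C(C)c1ccc(NS(C)(=O)=O)c(F)c1` gives 9.1 nM
Compound 2 `CC(C(=O)NCc1ccc(C(F)(F)F)nc1NC1CCCCC1)c1ccc(NS(C)(=O)=O)c(F)c1` gives 20.4 nM
Compound 3 `Cc1ccc(Nc2nc(C(F)(F)F)ccc2CNC(=O)C(C)c2ccc(NS(C)(=O)=O)c(F)c2)cc1C` gives 39.3 nM

Three compounds share one core and differ only in the group carried on a nitrogen on an aromatic ring. In a functional assay on CHO-K1 cells for antagonist activity at transient receptor potential cation channel subfamily V member 1 (Homo sapiens), read by FLIPR (a lower number here means a stronger inhibitor, a higher number a weaker inhibitor), compound 1 has the lowest number of the three. The change from butyl to cyclohexyl gives a 2.2-fold higher number from compound 1 to compound 2 (0.35 log units; beyond the scatter), and the change from butyl to 3,4-dimethylphenyl gives a 4.3-fold higher number from compound 1 to compound 3 (0.64 log units; beyond the scatter). Compound 3 stands at the highest number of the three, but its separation from compound 2 is a 1.9-fold higher number from compound 2 to compound 3 (0.28 log units; within the scatter), so the two cannot be placed in order.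

Compound 4 `Cc1ccc(Cl)cc1Nc1nc(C(F)(F)F)ccc1CNC(=O)C(C)c1ccc(NS(C)(=O)=O)c(F)c1` has not been measured. Its difference from compound 3 is 5-chloro-2-methylphenyl in place of 3,4-dimethylphenyl on a nitrogen on an aromatic ring. All measured steps concern the group on this nitrogen, yet none replaces one aromatic group by another; they only show that going from a chain to a ring here moves the number by modest amounts. Compound 4 is therefore expected to stay close to compound 3, with a step of a 1.0-fold higher number from compound 3 to compound 4 (0.01 log units; within the scatter) in this assay. The estimate for compound 4 is 40 nM, with a range from 14 nM to 120 nM.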

Compound 4, inhibition constant: 14 nM
Compound 4: the middle estimate sits 2.9-fold (0.46 log units) above what was measured; measured number inside the range.
By their numbers in this assay, from the lowest: compounds 1, 4, 2 and 3 (each within the scatter of the next, the first and the last beyond it).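

For the compounds shown here, the step from 3,4-dimethylphenyl to 5-chloro-2-methylphenyl is the first to replace one aromatic group by another on this nitrogen, and in this assay it gives a 2.8-fold lower number from compound 3 to compound 4 (0.45 log units; beyond the scatter), so the substituents on the aromatic group matter, even though the two groups have the same number of heavy atoms. The higher number of compound 3 therefore does not hold for every aromatic group here: a 1.5-fold lower number from compound 2 to compound 4 (0.16 log units; within the scatter) and a 1.5-fold higher number from compound 1 to compound 4 (0.19 log units; within the scatter) leave compound 4 unseparated from both the cyclohexyl and the butyl compounds, although compound 3 remains separated from compound 1. Nothing available says which part of the change, the chlorine or the different placing of the methyl, accounts for the step.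

Open, on these data alone, is how an unsubstituted phenyl, a chlorophenyl without a methyl or a single methylphenyl without a chlorine would stand on this nitrogen, so the share of each substituent stays unseparated. Also open, as far as these compounds go, is how a chain ending in an amine or a carboxylic acid, or a chain longer than butyl, would read in this assay.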